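Fluoro for Methoxy at the Edge of Detection

The compounds below may be only part of what the source reports. "The series", "measured", "known", "first", "only" and "open" are said of these compounds alone.

Compound 2 `COc1ccc(NC(=O)c2cccc(/C=C3\CC(=O)N(c4ccccc4)C3=O)c2)cc1` carries a methoxy group on the outer aromatic ring of the shared core. In an ADME assay on SW480 cells (Homo sapiens) for cytotoxicity, read by MTT assay, with a stated time of 72 h (a lower number here means a stronger inhibitor, a higher number a weaker inhibitor), compound 2 gives only a limit, > 100000 nM, and not a number. Compound 1 `CCc1ccc(NC(=O)c2cccc(/C=C3\CC(=O)N(c4ccccc4)C3=O)c2)cc1` is related to it by the step that the two limits leave unreadable from compound 1 to compound 2, whose size the two limits leave unreadable. In this assay compound 1 likewise gives only a limit, > 100000 nM. Both values sit together at the limit of > 100000 nM in this assay, at which 2 of the 2 values shown sit, so the swap between ethyl and methoxy shows nothing either way.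

Compound 3 `O=C(Nc1ccc(F)cc1)c1cccc(/C=C2\CC(=O)N(c3ccccc3)C2=O)c1` is reached from compound 2 by the change (fluoro in place of methoxy on an aromatic carbon). Only one measured step bears on this change, and its size is hidden; the two measured compounds have so far shown no reading inside the measurable range, so there is no evidence that the group in this place moves the result out of it. The expectation is that compound 3 stays there too, a step of a number no higher from compound 2 to compound 3 (the limit leaves the size open) that amounts to nothing beyond the scatter. Compound 3 is therefore estimated at 100000 nM in this assay, with a range from 30000 nM to 300000 nM.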

Compound 3, half-maximal inhibitory concentration: > 100000 nM
Compound 3: no number, only a limit (the forecaster's own chance of this, stated with the estimate: 80%); the middle value sits exactly at the limit.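

Compound 3, like compound 1 and compound 2, gives only a limit and not a number, so none of the steps among these three compounds can be read. All three readings in this assay coincide: the limit of > 100000 nM in this assay, at which 3 of the 3 values shown sit.

The compounds shown leave open whether ethyl, methoxy and fluoro differ at all in this place, and how strongly any of these compounds acts on the cells.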